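Compound 3: a new group on the sulfonyl sulfur

The source may hold more compounds than are shown below. What is called first, only, known or untested is meant among the compounds shown, and "the series" means these compounds.

Compound 1 `CC1=C(CC(=O)N(C)CCN(C)S(=O)(=O)c2ccccc2)c2cc(F)ccc2/C1=C\c1ccc([S+](C)[O-])cc1` gives 8200 nM
Compound 2 `CC1=C(CC(=O)N(C)CCN(C)S(=O)(=O)c2ccc(C)cc2)c2cc(F)ccc2/C1=C\c1ccc([S+](C)[O-])cc1` gives 11000 nM

Both values come from a functional assay on PC-3 cells (Homo sapiens) for inhibition, read by CellTiter-Glo, with a stated time of 72 h (on this read-out higher numbers stand for lower toxicity in this test and lower numbers for higher toxicity in this test), and compound 2 stands level with compound 1 within the usual scatter of such measurements. The next structure is compound 3 `CC1=C(CC(=O)N(C)CCN(C)S(=O)(=O)c2cccc3ccccc23)c2cc(F)ccc2/C1=C\c1ccc([S+](C)[O-])cc1` and it carries naphthalen-1-yl in place of 4-methylphenyl on a sulfonyl sulfur, a swap counted in full as naphthalen-1-yl in place of 4-methylphenyl on a sulfonyl sulfur here. Among the measured compounds shown here, only one measured step bears on this change: methyl in place of hydrogen on an aromatic carbon gave a 1.3-fold higher number from compound 1 to compound 2 (0.13 log units; within the scatter) and that is a small step. For the measured compounds named here, no measured compound carries naphthalen-1-yl, which leaves this guide weak. In this assay no step beyond the scatter is expected in either direction. The expected result is a 1.2-fold lower number from compound 2 to compound 3 (0.09 log units; within the scatter) with real uncertainty around it. Compound 3 is estimated at 9000 nM and is expected to fall from 3500 nM to 20000 nM when measured.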

Compound 3, half-maximal cytotoxic concentration: 8960 nM
The estimate for compound 3 lay 1.0-fold (0.00 log units) above the measured number, within the range that was stated.
By their numbers in this assay, from the lowest: compounds 1, 3 and 2 (each within the scatter of the next).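

In this assay, the sulfonyl sulfur now carries naphthalen-1-yl, with 2 six-membered aromatic rings instead of the one in 4-methylphenyl, and this much larger swap than the earlier added methyl still gives only a 1.2-fold lower number from compound 2 to compound 3 (0.09 log units; within the scatter). Set against the phenyl group, the same group gives a 1.1-fold higher number from compound 1 to compound 3 (0.04 log units; within the scatter), so compound 1, compound 2 and compound 3 all stand level, and in these three compounds the size of the carbon-only aromatic group on this sulfur does not separate them. Nothing measured here gives a reason for this result.

The compounds shown leave open whether an aromatic group is needed on this sulfur at all, or whether a plain methyl or a longer chain would give a similar number. They also leave open whether an amine or a carboxylic acid on the phenyl ring would move the number beyond the scatter.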